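Changing the Ester Group: From Compound 2 to Compound 4

This account rests on a few compounds, and the source may have more. Where it says the series, first, only, none or still open, it means among the compounds named here.

Compound 1 `COc1cc(C2Oc3cc([C@H]4Oc5cc(O)cc(O)c5C(=O)[C@@H]4O)ccc3OC2COC(=O)c2cc([N+](=O)[O-])cc([N+](=O)[O-])c2)ccc1O`: 205000 nM
Compound 2 `COc1cc(C2Oc3cc([C@H]4Oc5cc(O)cc(O)c5C(=O)[C@@H]4O)ccc3OC2COC(=O)c2cc(OC)c(OC)c(OC)c2)ccc1O`: 94800 nM
Compound 3 `COc1cc(C2Oc3cc([C@H]4Oc5cc(O)cc(O)c5C(=O)[C@@H]4O)ccc3OC2COC(=O)c2cc(N)cc([N+](=O)[O-])c2)ccc1O`: a limit, > 300000 nM
Compound 4 `COc1cc(C2Oc3cc([C@H]4Oc5cc(O)cc(O)c5C(=O)[C@@H]4O)ccc3OC2COC(=O)/C=C/c2ccc(Br)cc2)ccc1O`: not yet measured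

In a functional assay, read by spectrophotometry, with a stated time of 30 min (a lower number here means that less compound is needed, a higher number that more compound is needed for the effect), compound 2 gives 94800 nM, the lowest of the two numbers shown, with compound 1 nearest at 205000 nM; the step is a 2.2-fold lower number from compound 1 to compound 2 (0.33 log units; beyond the scatter). For compound 3 the assay reports only a limit, > 300000 nM. Compound 4 carries a different ester group: 2-(4-bromophenyl)ethenyl in place of 3,4,5-trimethoxyphenyl on a carbonyl carbon. Going by the values given here, no measured step replaces the ester group with a group of this kind; the steps that do alter it, a 2.2-fold lower number from compound 1 to compound 2 (0.33 log units; beyond the scatter) and an at least 3.1-fold higher number from compound 2 to compound 3 (0.50 log units; beyond the scatter), are both modest. A similar, modest shift in no clear direction is expected, so the estimated step is a 1.3-fold higher number from compound 2 to compound 4 (0.10 log units; within the scatter). Compound 4 is thus expected to give 120000 nM, between 50000 nM and 300000 nM.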

Compound 4, half-maximal effective concentration: 88900 nM
Compound 4: middle estimate off by 1.3-fold (0.13 log units), on the high side, and the stated range covers the measured number.
By their numbers in this assay, from the lowest: compounds 4 and 2 (each within the scatter of the next); then compound 1. At a limit, above all of these: compound 3.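

The ester position takes two quite different groups on the carbonyl carbon with no difference beyond the scatter: a 1.1-fold lower number from compound 2 to compound 4 (0.03 log units; within the scatter). Compound 4 also separates from the two nitro-bearing esters, with a 2.3-fold lower number from compound 1 to compound 4 (0.36 log units; beyond the scatter) and an at least 3.3-fold lower number from compound 3 to compound 4 (0.52 log units; beyond the scatter). Compound 3 is known only as a limit: the limit of > 300000 nM in this assay, at which 1 of the 4 values shown sits.

Still open, on these data alone, is what the bromine and the double bond each contribute to compound 4. As far as these compounds go, it is also open whether a carboxylic acid or a longer saturated chain on this carbonyl carbon would give a similar number.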